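Removing the piperazine from compound 2

The source may report more compounds than this note shows. Statements on the series, on what has been measured and on what is new or still open speak of the compounds shown alone.

In a functional assay on HCT-116 cells (Homo sapiens) for antiproliferative activity, read by sulforhodamine B assay, with a stated time of 72 h (a lower number here means a stronger inhibitor, a higher number a weaker inhibitor), compound 1 (`COc1ncc(-c2ccc3ncc(NCC4CCCCC4)c(OC)c3c2)cc1NS(=O)(=O)c1ccc(F)cc1F`) gives 13600 nM and compound 2 (`COc1ncc(-c2ccc3ncc(NC(=O)CN4CCN(C)CC4)c(OC)c3c2)cc1NS(=O)(=O)c1ccc(F)cc1F`) gives 1540 nM as the lower of the two numbers, which makes it the stronger inhibitor of this pair. Compound 3 (`COc1ncc(-c2ccc3ncc(NC(C)=O)c(OC)c3c2)cc1NS(=O)(=O)c1ccc(F)cc1F`) carries hydrogen in place of 4-methylpiperazin-1-yl on a saturated chain carbon bound to a carbonyl carbon and so ends in acetamido. Going by the values given here, the only measured step that bears on this (an 8.8-fold lower number from compound 1 to compound 2 (0.95 log units; beyond the scatter)) put ((4-methylpiperazin-1-yl)methyl)carbonyl in place of cyclohexylmethyl. Among the compounds with values here, that modest step swapped the whole group, and no measurement yet isolates the piperazine ring. In this assay only a small change is therefore expected (a 1.3-fold lower number from compound 2 to compound 3 (0.11 log units; within the scatter)) and a step in either direction remains possible. Compound 3 is expected to give about 1200 nM with an estimated range of 300 nM to 5000 nM around that figure.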

Compound 3, half-maximal inhibitory concentration: 550 nM
Compound 3: middle estimate off by 2.2-fold (0.34 log units), on the high side; measured number inside the range.
By their numbers in this assay, from the lowest: compound 3; then compound 2; then compound 1.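

Going by these compounds alone, removing the 4-methylpiperazin-1-yl group isolates the ring for the first time in this assay: the step with hydrogen in its place on a saturated chain carbon bound to a carbonyl carbon is a 2.8-fold lower number from compound 2 to compound 3 (0.45 log units; beyond the scatter) and lies beyond the scatter. The piperazine is therefore not needed for the gain over cyclohexylmethyl, since the plain acetyl group on a nitrogen on an aromatic ring gives a larger step (a 25-fold lower number from compound 1 to compound 3 (1.39 log units; beyond the scatter)). Nothing here explains why either step goes this way.

From the compounds shown here alone, compound 1 and compound 3 differ in a whole group, so the role of the carbonyl stays open, and an ethyl group on that nitrogen would help to separate it from size. Also open, going by these compounds, is how a small amine such as dimethylamino on the chain carbon compares with hydrogen.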